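The source may report more compounds than this note shows. Statements on the series, on what has been measured and on what is new or still open speak of the compounds shown alone.

Three compounds have been measured in a functional assay (blood) for inhibition, with Homo sapiens as the target; a lower number here means a stronger inhibitor, a higher number a weaker inhibitor:

Compound 1 `COC1(c2csc(Sc3ccc4c(c3)OCC/C4=N\OCC#N)c2)CCOCC1` gives 60 nM
Compound 2 `COC1(c2cc(F)cc(Sc3ccc4c(c3)CC/C4=N\O)c2)CCOCC1` gives 290 nM
Compound 3 `COC1(c2cc(F)cc(Sc3ccc4c(c3)CC/C4=N\OCC#N)c2)CCOCC1` gives 30 nM

Compound 3 and compound 2 differ in one place, (hydrogen in place of cyanomethyl on an oxygen), and this change produced a 9.7-fold higher number from compound 3 to compound 2 (0.99 log units; beyond the scatter). Compound 4 `COC1(c2csc(Sc3ccc4c(c3)OCC/C4=N\O)c2)CCOCC1` has not been measured yet. It arises from compound 1 by the same change, (hydrogen in place of cyanomethyl on an oxygen), at the same place. How the core of compound 1 differs from the core of compound 3 is not broken down here, and compound 1 and compound 3 give numbers within the usual scatter of each other. The step from compound 1 to compound 4 is expected to be a 9.7-fold higher number from compound 1 to compound 4 (0.99 log units; beyond the scatter), resting on a 9.7-fold higher number from compound 3 to compound 2 (0.99 log units; beyond the scatter) applied to compound 1 at 60 nM. Compound 4 is therefore estimated at 580 nM in this assay, expected to fall between 250 nM and 1400 nM.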

Compound 4, half-maximal inhibitory concentration: 40 nM
The estimate for compound 4 lay 15-fold (1.16 log units) above the measured number, outside the stated range (below it).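

In this assay, replacing cyanomethyl with hydrogen on the oxygen gave a 1.5-fold lower number from compound 1 to compound 4 (0.18 log units; within the scatter). The effect of this change therefore depends on the core, and its size on one core cannot simply be carried over to the other: the same change on two cores in this assay, a 9.7-fold higher number (0.99 log units; beyond the scatter) from compound 3 to compound 2 and a 1.5-fold lower number (0.18 log units; within the scatter) from compound 1 to compound 4, 15-fold (1.16 log units) apart, beyond the scatter of two such steps The two cores differ in more than one place, and these two pairs show neither which difference matters nor why, nor how the change would behave on any further core.

The compounds shown carry only hydrogen or cyanomethyl on this oxygen. From the compounds shown here alone, it remains open how a methyl group or a longer chain ending in a nitrile would behave there on each of the two cores.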